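Moving the Pyridine Nitrogen on a Weakly Antiproliferative Core

This account rests on a few compounds, and the source may have more. Where it says the series, first, only, none or still open, it means among the compounds named here.

Compound 1 `Cc1cn2c(/C=N/NC(=N)N)c(-c3ccncc3)nc2s1` gives 39800 nM
Compound 2 `Cc1sc2nc(-c3ccncc3)c(/C=N/NC(=N)N)n2c1C` gives 83200 nM
Compound 3 `N=C(N)N/N=C/c1c(-c2ccncc2)nc2sc(Cl)cn12` gives 13800 nM

All three values come from a functional assay (Homo sapiens) for antiproliferative activity; on this read-out lower numbers stand for stronger inhibition of growth and higher numbers for weaker inhibition of growth. Compound 1 stands second highest of the three numbers. Its nearest neighbour is compound 2, reached by a 2.1-fold higher number from compound 1 to compound 2 (0.32 log units; beyond the scatter), a change of methyl in place of hydrogen on an aromatic carbon. Furthest from it is compound 3, reached by a 2.9-fold lower number from compound 1 to compound 3 (0.46 log units; beyond the scatter), a change of chloro in place of methyl on an aromatic carbon.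

Compound 4 `Cc1cn2c(/C=N/NC(=N)N)c(-c3ccccn3)nc2s1` differs from compound 1 by pyridin-2-yl in place of pyridin-4-yl on an aromatic carbon, the change sitting on an aromatic carbon of a five-membered aromatic ring with two nitrogen, part of a fused system of two rings, next to the ring nitrogen. Neither measured step touches this position: both alter the group on the other ring of the shared core, leaving the pyridine untouched. For the measured compounds named here, there is therefore no direct precedent, and the two measured steps only show that single changes on this core have so far moved this assay modestly. The step of a 1.0-fold higher number from compound 1 to compound 4 (0.00 log units; within the scatter) is expected to be none beyond the scatter, with a wide margin of doubt. Compound 4 is thus estimated at 40000 nM, within a range of 10000 nM to 160000 nM.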

Compound 4, concentration for total growth inhibition: 28800 nM
Beside the measured number, compound 4's estimate is 1.4-fold (0.14 log units) above it, within the range that was stated.
By their numbers in this assay, from the lowest: compound 3; then compounds 4 and 1 (each within the scatter of the next); then compound 2.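

In this assay, replacing pyridin-4-yl with pyridin-2-yl gives a 1.4-fold lower number from compound 1 to compound 4 (0.14 log units; within the scatter), so the two compounds stand within the scatter of each other and this swap, on an aromatic carbon next to the ring nitrogen, leaves the read-out where it was. For the compounds shown here, this is the first reading at this position, and it is the only one of the three single steps from compound 1 that stays within the scatter, whereas the methyl and chloro steps elsewhere on the shared core go beyond it, if only modestly. On these figures the place of the nitrogen within the pyridine is not a sensitive point for growth inhibition in this series, although nothing measured here offers an explanation for that.

The compounds shown leave open whether pyridin-3-yl, or a plain phenyl ring with no ring nitrogen at all, would sit equally well at this position. They also leave open whether pyridin-2-yl would keep pace with pyridin-4-yl when the methyl on the other ring gives way to the chloro of compound 3, and a single pair cannot settle that.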